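A few compounds are considered here, and "the series" means these few. Any claim that something is new, unique, unknown or untested is made for them only; others in the source may bear on it.

In a functional assay on QGY-7703 cells (Homo sapiens) for cytotoxicity, read by MTT assay, with a stated time of 24 h (a higher number here means a weaker inhibitor, a lower number a stronger inhibitor), compound 1 (`COc1ccc(/C=C2\CN(C)C/C(=C\c3ccncc3)C2=O)c(OC)c1OC`) gives 8350 nM and compound 2 (`O=C1/C(=C/c2cccnc2)CN(S(=O)(=O)c2ccc([N+](=O)[O-])cc2)C/C1=C\c1ccccc1F`) gives 5600 nM, two values within the usual scatter of each other. Compound 3 (`CC(=O)Nc1ccc(S(=O)(=O)N2C/C(=C\c3cccnc3)C(=O)/C(=C/c3ccccc3F)C2)cc1`) has not yet been measured there. It keeps the rest of compound 2 and changes one group: acetamido in place of nitro on an aromatic carbon, para to a large group (acetamido in place of nitro on an aromatic carbon). Among the measured compounds shown here, the two measured compounds differ in more than one place, so no measured step shows what this change does. With nothing to set a direction, no step beyond the scatter is expected in this assay, and the expectation starts from compound 2 at 5600 nM. The estimated change is a 1.1-fold higher number from compound 2 to compound 3 (0.03 log units; within the scatter). For compound 3 the expected value is 6000 nM, with an estimated range from 2400 nM to 15000 nM.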

Compound 3, half-maximal inhibitory concentration: 9640 nM
For compound 3 the middle estimate is 1.6-fold (0.21 log units) below the measured one; the range from low to high includes it.
By their numbers in this assay, from the lowest: compounds 2, 1 and 3 (each within the scatter of the next).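

Acetamido in place of nitro on an aromatic carbon, para to a large group, gives a 1.7-fold higher number from compound 2 to compound 3 (0.24 log units; within the scatter) in this assay and is the first single change that can be read at this position. This position therefore takes a swap from 4-nitrophenyl to 4-acetamidophenyl, which brings in the hydrogen-bond donor of acetamido, with no step beyond the scatter. Nothing measured here bears on what lies behind this step.

On these data alone, whether an amine or a carboxylic acid at this place would give a step beyond the scatter remains open, as does the outcome for a longer chain on the acetamido group. Compound 1 differs from the other two in more than one place, so it leaves open whether the same change would read alike on a different core.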